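Chloro for fluoro on the phenol ring of compound 1

This account rests on a few compounds, and the source may have more. Where it says the series, first, only, none or still open, it means among the compounds named here.

Measured in a functional assay, with a stated time of 30 min; a higher number here means a weaker inhibitor, a lower number a stronger inhibitor:
- compound 1 `Oc1ccc(F)cc1/C=N/c1ccc(OCc2ccccc2)cc1`: > 200000 nM
- compound 2 `Oc1ccc(/C=N/c2ccc(OCc3ccccc3)cc2)c(O)c1O`: 43400 nM
- compound 3 `Oc1ccc2ccccc2c1/C=N/c1ccc(OCc2ccccc2)cc1`: > 200000 nM

Compound 1 reports only a limit of this assay, > 200000 nM, not a number. Compound 3 likewise stops at a limit, > 200000 nM. Compound 2 alone gives a number, 43400 nM. Of the three values shown, most sit at the limit of > 200000 nM in this assay, at which 2 of the 3 values shown sit, so compound 1 stands at the weak end of what the assay can register.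

Compound 4 `Oc1ccc(Cl)cc1/C=N/c1ccc(OCc2ccccc2)cc1` differs from compound 1 by chloro in place of fluoro on an aromatic carbon. Among the measured compounds shown here, no measured pair of compounds shares this change, so the size of the step is unknown. For compound 4 a step that the limit leaves unreadable from compound 1 to compound 4 is expected, that is, nothing beyond the scatter, with a real chance that only a limit is reported again. Compound 4 is estimated at 250000 nM, in the range 60000 nM to 1000000 nM.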

Compound 4, half-maximal inhibitory concentration: > 200000 nM
Compound 4 ended at the assay's limit; the forecaster's own chance of this, stated with the estimate: 75%; the middle value does not contradict the limit.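

Compound 1 and compound 4 both end at a limit of this assay, so no step can be read between them: the limit of > 200000 nM in this assay, at which 3 of the 4 values shown sit. The compounds shown leave open whether chloro in place of fluoro changes inhibition at all on this core.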